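The source may report more compounds than this note shows. Statements on the series, on what has been measured and on what is new or still open speak of the compounds shown alone.

Compounds measured:
- compound 1 `COc1cc2nc(N3CCC(N4CCCC(CO)C4)CC3)nc(NC3CCOCC3)c2cc1OC`: "not determined" (no result reported)
- compound 2 `COc1cc2nc(N3CCC(N4CCCC(CO)C4)CC3)nc(NC3Cc4cc(Cl)ccc4N3)c2cc1OC`: "not determined" (no result reported)
- compound 3 `COc1cc2nc(N3CCC(N4CCCC(CO)C4)CC3)nc(Nc3ccc(Cl)cc3)c2cc1OC`: 58 nM

Within the data shown here, in an in vitro functional assay on B300-19 cells for antagonist activity at C-C chemokine receptor type 4 (Mus musculus) (a lower number here means a stronger inhibitor, a higher number a weaker inhibitor), compound 3 gives 58 nM, and it is the only compound of the set with a reported number; compound 1 and compound 2 carry no result, so no comparison among measured compounds can be drawn. Compound 4 `COCC1CCCN(C2CCN(c3nc(Nc4ccc(Cl)cc4)c4cc(OC)c(OC)cc4n3)CC2)C1` differs from compound 3 in one place: methyl in place of hydrogen on an oxygen on a saturated carbon. Among the measured compounds shown here, since no step between measured compounds is known, the size of this step can only be guessed; the step of a 1.4-fold higher number from compound 3 to compound 4 (0.14 log units; within the scatter) is expected to stay within the usual scatter, with at most a slight weakening. Compound 4 is therefore estimated at 80 nM, with a likely range from 25 nM to 260 nM.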

Compound 4, half-maximal inhibitory concentration: 230 nM
For compound 4 the middle estimate is 2.9-fold (0.46 log units) below the measured one; the measured number falls inside the stated range.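

Among these compounds, this is the first readable step at this position. In this assay, exchanging 3-(hydroxymethyl)piperidin-1-yl for 3-(methoxymethyl)piperidin-1-yl gives a 4.0-fold higher number from compound 3 to compound 4 (0.60 log units; beyond the scatter), so methyl in place of hydrogen on this oxygen weakens inhibition modestly but beyond the scatter. Nothing shown here accounts for the loss. The compounds shown leave open how an amine, a carboxylic acid or a longer chain such as ethoxymethyl would fare at this position. They also leave open whether removing the hydroxy altogether would cost more or less than adding the methyl.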